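Methyl retained, terminal aryl exchanged: compound 1 to compound 4

The compounds below may be only part of what the source reports. "The series", "measured", "known", "first", "only" and "open" are said of these compounds alone.

Measured in a functional assay on SiHa cells (Homo sapiens) for inhibition, read by sulforhodamine B assay; a lower number here means a stronger inhibitor of growth, a higher number a weaker inhibitor of growth:
- compound 1 `Cc1ccc2[nH]c(-c3ccc(-c4ccc(-c5cccc(Cl)c5)cc4)cc3)nc2c1`: 3600 nM
- compound 2 `FC(F)(F)Oc1ccc(-c2ccc(-c3ccc(-c4nc5ccccc5[nH]4)cc3)cc2)cc1`: 38400 nM
- compound 3 `Clc1cccc(-c2ccc(-c3ccc(-c4nc5ccccc5[nH]4)cc3)cc2)c1`: 100000 nM

Compound 1 has the lowest number of the three, and its gaps to compound 2 and compound 3 both lie beyond the scatter. Compound 4 `Cc1ccc2[nH]c(-c3ccc(-c4ccc(-c5ccc(C(F)(F)F)cc5)cc4)cc3)nc2c1` keeps the methyl group of compound 1 and exchanges one aryl group: 4-(trifluoromethyl)phenyl in place of 3-chlorophenyl on an aromatic carbon.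

Within the data shown here, no measured step makes this exchange. Among the measured compounds shown here, the one measured step, a 28-fold higher number from compound 1 to compound 3 (1.44 log units; beyond the scatter), is large, but it removes the methyl group, which compound 4 retains. It therefore gives no direct size for the change at hand. Compound 2 and compound 3 also lack the methyl group and carry different aryl substituents. Compound 2, with its trifluoromethoxy group, gives 38400 nM, whereas compound 3, with the 3-chlorophenyl group, gives 100000 nM. This gap offers only a weak hint towards a lower number for compound 4, since trifluoromethoxy is not the group entering here. No step beyond the scatter is therefore expected in this assay, and a step as large as the methyl step is not anticipated.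

The estimated step is a 1.4-fold lower number from compound 1 to compound 4 (0.16 log units; within the scatter).

Compound 4 is estimated at 2500 nM, with an expected range from 700 nM to 12000 nM.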

Compound 4, concentration for 50% growth inhibition: 33200 nM
Estimate against measurement, compound 4: 13-fold (1.12 log units) below; measured number outside the range, above it.
By their numbers in this assay, from the lowest: compound 1; then compounds 4 and 2 (each within the scatter of the next); then compound 3.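

In this assay, the terminal aryl group proves to be a sensitive place in the methyl-bearing compounds, with a 9.2-fold higher number from compound 1 to compound 4 (0.96 log units; beyond the scatter) when 4-(trifluoromethyl)phenyl replaces 3-chlorophenyl and the rest of the structure stays the same. Among these compounds, the earlier compounds gave only one single-change comparison, a 28-fold higher number from compound 1 to compound 3 (1.44 log units; beyond the scatter) on loss of the methyl group, so the new step shows that the methyl group is not the only place in compound 1 where one change moves the number beyond the scatter. No measurement at hand accounts for the higher number of compound 4.

The exchange alters both the substituent and where it sits on the terminal ring, and the compounds shown do not separate these two changes. From the compounds shown here alone, how an amine or a carboxylic acid on that ring would read in this assay stays open, as does whether the effect of the terminal aryl exchange is the same without the methyl group.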